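This account rests on a few compounds, and the source may have more. Where it says the series, first, only, none or still open, it means among the compounds named here.

Compound 3, `COc1ccc(-c2cc(-c3ccc(C(F)(F)F)cc3)cnc2N)cn1`, stands in an in vitro ADME assay on microsomes from liver (Homo sapiens) for metabolic stability (a lower number here means slower removal, a higher number faster removal of the compound), at 6.1 mL.min-1.g-1. Compound 1, `CNS(=O)(=O)c1ccc(-c2cnc(N)c(-c3ccc(OC)nc3)c2)cc1`, gives in this assay 9.6 mL.min-1.g-1, and the step of a 1.6-fold lower number from compound 1 to compound 3 (0.20 log units; within the scatter) stays within the scatter. Compound 2, `COc1ccc(-c2cc(-c3ccc(NS(C)(=O)=O)cc3)cnc2N)cn1`, is reported in this assay only as a limit, < 7 mL.min-1.g-1 (the limit of < 7 mL.min-1.g-1 in this assay, at which 1 of the 3 values shown sits). The step that the limit leaves unreadable from compound 2 to compound 3 therefore cannot be read.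

Compound 4, `COc1ccc(-c2cc(-c3ccc(C(=O)O)cc3)cnc2N)cn1`, differs from compound 3 in one place: carboxy in place of trifluoromethyl on an aromatic carbon. Of the measured steps, only a 1.6-fold lower number from compound 1 to compound 3 (0.20 log units; within the scatter) and a step that the limit leaves unreadable from compound 2 to compound 3 touch the same aromatic carbon, and neither involves carboxy; one is within the scatter, the other unreadable. Nothing measured here shows a change at this carbon moving the clearance in this assay beyond the scatter. The step from compound 3 to compound 4 is therefore expected to be small, a 1.2-fold lower number from compound 3 to compound 4 (0.09 log units; within the scatter), with the number for compound 4 estimated at 5 mL.min-1.g-1, between 2 mL.min-1.g-1 and 12 mL.min-1.g-1, and since this lies close to the assay's limit, a limit rather than a number may well be reported for compound 4.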

Compound 4, intrinsic clearance in microsomes: < 7 mL.min-1.g-1
Compound 4 ended at the assay's limit (the forecaster's own chance of this, stated with the estimate: 60%); the middle value lies beyond the limit too.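

Compound 4 is reported in this assay only as a limit, < 7 mL.min-1.g-1, which makes carboxy the second group on this aromatic carbon to end at a limit: the limit of < 7 mL.min-1.g-1 in this assay, at which 2 of the 4 values shown sit. For the compounds shown here, the one step that can be read, an at least 1.3-fold lower number from compound 1 to compound 4 (0.13 log units; that floor lies within the scatter), gives only a floor, and the steps from compound 3 and compound 2 to compound 4 cannot be read. Going by these compounds alone, the change to carboxy, the only group here counted with both a hydrogen-bond donor and a hydrogen-bond acceptor under this comparison, therefore still shows no step at this carbon that is printed as beyond the scatter.

Going by these compounds, whether carboxy and trifluoromethyl differ at all in intrinsic clearance remains open. On these data alone, it also remains open whether an amine or a primary amide on this aromatic carbon would give a readable number.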